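From 2-methoxyphenyl to 4-methoxyphenyl on the shared core

The source may hold more compounds than are shown below. What is called first, only, known or untested is meant among the compounds shown, and "the series" means these compounds.

Of the compounds shown here, three have numbers so far in a physicochemical assay for inhibition, with a stated time of 1 h (on this read-out lower numbers stand for stronger inhibition and higher numbers for weaker inhibition), and they are spread apart. Compound 1 `COc1ccccc1Nc1nnc(CSCc2cc(C(C)(C)C)c(O)c(C(C)(C)C)c2)s1` gives 13200 nM and takes the middle place of the three. Compound 2 `COc1ccc(NC(=S)NNC(=O)CSCc2cc(C(C)(C)C)c(O)c(C(C)(C)C)c2)cc1` gives 30100 nM as the highest number, and compound 3 `COc1ccc(-n2c(S)nnc2CSCc2cc(C(C)(C)C)c(O)c(C(C)(C)C)c2)cc1` gives 2850 nM as the lowest. Both gaps to compound 1 lie beyond the scatter.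

The next compound to be read is compound 4 `COc1ccc(Nc2nnc(CSCc3cc(C(C)(C)C)c(O)c(C(C)(C)C)c3)s2)cc1` with the same atoms as compound 1 joined differently. 4-methoxyphenyl in place of 2-methoxyphenyl on a nitrogen on an aromatic ring is the whole difference between them, with 4-methoxyphenyl in place of 2-methoxyphenyl on a nitrogen on an aromatic ring.

Going by the values given here, no measured pair isolates this change. Compound 2 and compound 3 also carry 4-methoxyphenyl, but each on a core different from that of compound 1, so neither gives a direct reading of the swap. With nothing measured to argue for a large move, only a slight shift towards stronger inhibition is expected. The estimated step is a 1.3-fold lower number from compound 1 to compound 4 (0.12 log units; within the scatter) and is expected to stay within the scatter. For compound 4 the estimated value in this assay is 10000 nM with an expected range of 4000 nM to 25000 nM for the coming measurement.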

Compound 4, half-maximal inhibitory concentration: 7980 nM
Estimate against measurement, compound 4: 1.3-fold (0.10 log units) above; the measured number falls inside the stated range.
By their numbers in this assay, from the lowest: compound 3; then compounds 4 and 1 (each within the scatter of the next); then compound 2.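

In this assay, going by these compounds alone, 4-methoxyphenyl in place of 2-methoxyphenyl on a nitrogen on an aromatic ring gives a 1.7-fold lower number from compound 1 to compound 4 (0.22 log units; within the scatter), the first direct reading of this swap on the shared core. The two compounds cannot be told apart on this read-out, so for this pair the 2-methoxyphenyl and 4-methoxyphenyl groups are interchangeable at this position, a finding that applies only to the core of compound 1 and compound 4. No measurement to hand bears on why the two compounds read alike.

Within the data shown here, whether this position stays as undemanding with a group of another kind, such as a carboxylic acid or an amine in place of the methoxy group, remains open, as the only groups seen here are these two methoxyphenyl groups. Also open is whether the same swap would read the same way on the cores of compound 2 and compound 3, where only 4-methoxyphenyl appears among the compounds shown.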